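The source may hold more compounds than are shown below. What is called first, only, known or untested is meant among the compounds shown, and "the series" means these compounds.

Of the compounds shown here, three have so far been measured in a functional assay on HepG2 cells (Homo sapiens) for antiproliferative activity, read by CCK-8 assay, with a stated time of 72 h, tested at 8 uM; a lower number here means a weaker effect, a higher number a stronger effect of the compound at the concentration tested. Compound 1 `CN1CCN(c2nc(Cl)nc3c2ncn3Cc2ccc(C(=O)Nc3ccccc3N)cc2)CC1` gives 75%. Compound 2 `CC(C)n1cnc2c(Nc3cccc(Cl)c3)nc(NCOCc3ccc(C(=O)Nc4ccccc4N)cc3)nc21` gives 60.5%. Compound 3 `Nc1ccccc1NC(=O)/C=C/c1ccc(Cn2cnc3c(Nc4cccc(Cl)c4)nc(Cl)nc32)cc1` gives 49.3%, the lowest of the three numbers: the nearest to it is compound 2, whose number is higher by a margin beyond the scatter, and the furthest is compound 1, whose number is higher by a still larger margin, also beyond the scatter.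

Compound 4 `Nc1ccccc1NC(=O)/C=C/c1ccc(Cn2cnc3c(NC4CCCCC4)nc(Cl)nc32)cc1` has not yet been measured. It differs from compound 3 in one place: cyclohexyl in place of 3-chlorophenyl on a nitrogen on an aromatic ring. Put another way, (3-chlorophenyl)amino becomes cyclohexylamino. Among the compounds with values here, no two measured compounds differ by this same change, so no measured step shows what it does here; the remaining part of compound 4 is the same as in compound 3.

With nothing to anchor the change, the expectation for the step in this assay is a small one, most likely not beyond the scatter, with a slight lean towards a weaker effect: the expected step from compound 3 to compound 4 is a number 4.3 percentage points lower from compound 3 to compound 4 (within the scatter). For compound 4 the expected value is 45%, with a range from 25% to 65%.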

Compound 4, a percentage reported as inhibition, at one concentration (the size of the read-out at that concentration, not a potency): 42.7%
Beside the measured number, compound 4's estimate is 2.3 percentage points above it; measured number inside the range.
By their numbers in this assay, from the lowest: compounds 4 and 3 (each within the scatter of the next); then compound 2; then compound 1.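

In this assay, within the data shown here, the swap on this nitrogen on an aromatic ring gives a number 6.6 percentage points lower from compound 3 to compound 4 (within the scatter) and is the first direct reading of this position, since no earlier pair of compounds differed in one place. The aromatic 3-chlorophenyl can therefore give way to the non-aromatic cyclohexyl, which also carries no chlorine, without a shift that stands out from the usual variation between repeats, at least at this single test concentration. No measurement at hand explains why these two groups read alike.

The step changes the ring type and removes the chlorine at once, so a plain phenyl group on the same nitrogen would be needed to read those two parts separately, and any effects that offset each other would stay hidden until then. Both groups are also six-carbon rings, which leaves open how a small methyl group, a longer open chain or a carboxylic acid would read here, and a percentage at one concentration cannot show whether compound 3 and compound 4 differ in potency.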